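Furan-3-yl in place of the lactam side group

The compounds below may be only part of what the source reports. "The series", "measured", "known", "first", "only" and "open" are said of these compounds alone.

- compound 1 `COC(=O)C(C)(O)[C@@](O)(C[C@H](C)CC/C=C(/C)CC/C=C(/C)CCCc1ccoc1)C(=O)OC` gives 46 ug/mL as a number
- compound 2 `COC(=O)C(C)(O)[C@](O)(C[C@H](C)CC/C=C(/C)CC/C=C(/C)CCCC1=CCN(CC(=O)O)C1=O)C(=O)OC` gives > 100 ug/mL as a limit

In a functional assay on K562 cells (Homo sapiens) for cytotoxicity, read by MTT assay (on this read-out higher numbers stand for lower toxicity in this test and lower numbers for higher toxicity in this test), compound 2 gives > 100 ug/mL as a limit and not a number. Compound 2 stands at the limit of > 100 ug/mL in this assay, at which 1 of the 2 values shown sits, in these notes. Going from compound 2 to compound 3 `COC(=O)C(C)(O)[C@](O)(C[C@H](C)CC/C=C(/C)CC/C=C(/C)CCCc1ccoc1)C(=O)OC` the change is a group of 5 heavy atoms (4 carbon, 1 oxygen; one five-membered aromatic ring with 1 hetero atom) in place of a group of 10 heavy atoms (6 carbon, 1 nitrogen, 3 oxygen; one five-membered non-aromatic ring with 1 hetero atom), on a saturated chain carbon, three bonds along the chain from a double-bonded chain carbon with the rest of the structure kept. Within the data shown here, no step between measured compounds sizes this change. Compound 1 carries the same furan-3-yl and gives 46 ug/mL in this assay so a move towards lower numbers, meaning higher toxicity, is expected. The expected step is an at least 2.2-fold lower number from compound 2 to compound 3 (0.34 log units; beyond the scatter) in size. Compound 3 is estimated at 45 ug/mL with an expected range of 18 ug/mL to 100 ug/mL for repeated measurements.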

Compound 3, concentration lethal to 50% of the cells: 34 ug/mL
Estimate against measurement, compound 3: 1.3-fold (0.12 log units) above, within the range that was stated.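

In this assay, among these compounds, the furan-3-yl in place of the lactam side group on this saturated chain carbon gives an at least 2.9-fold lower number from compound 2 to compound 3 (0.46 log units; beyond the scatter) and this is the first sizing of that change. The value of compound 2 is a limit and not a number: the limit of > 100 ug/mL in this assay, at which 1 of the 3 values shown sits. The stereo difference gives a 1.4-fold lower number from compound 1 to compound 3 (0.13 log units; within the scatter) and no order can be read from it: the fact that one of compounds 1 and 3 is drawn with a defined configuration and the other without, at the place where they differ.

Open, on these data alone, is whether a phenyl ring or an amine in place of furan-3-yl gives a number like that of compound 3 in this assay. Also open, as far as these compounds go, is how a longer chain ahead of the furan-3-yl would read.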